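The source may report more compounds than this note shows. Statements on the series, on what has been measured and on what is new or still open speak of the compounds shown alone.

In a functional assay on A2780 cells (Homo sapiens) for inhibition, read by trypan blue exclusion, with a stated time of 72 h (on this read-out lower numbers stand for stronger inhibition of growth and higher numbers for weaker inhibition of growth), compound 2 `Cc1c(-c2ccc(OC(=O)c3c[nH]cn3)cc2)[nH]c2ccccc12` gives > 20000 nM, which is a limit of the assay and not a number. Going by the values given here, the only other measured compound, compound 1 `Cc1ncsc1C(=O)Oc1ccc(-c2[nH]c3ccccc3c2C)cc1`, gives 13000 nM in this assay. Among the compounds with values here, the single measured step, an at least 1.5-fold higher number from compound 1 to compound 2 (0.18 log units; that floor lies within the scatter), exchanges one group on the carbonyl carbon for another, so it offers only weak guidance. Compound 3 `Cc1c(-c2ccc(O)cc2)[nH]c2ccccc12` goes further and loses the whole group on the oxygen: hydrogen in place of (1H-imidazol-4-yl)carbonyl on an oxygen on an aromatic ring. Within the data shown here, no measured step removes this group, so its effect has no direct precedent. Among the measured compounds shown here, since compound 1 at 13000 nM is the only firm number nearby, growth inhibition in the same weak range is expected. Compound 3 may also reach the limit of the assay. The expected change is small, an at least 1.2-fold lower number from compound 2 to compound 3 (0.09 log units; that floor lies within the scatter). For compound 3, the estimated value is 16000 nM, with an expected range from 6000 nM to 40000 nM.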

Compound 3, concentration for 50% growth inhibition: > 20000 nM
Compound 3: only a limit was reported (the forecaster's own chance of this, stated with the estimate: 45%); at least 1.2-fold (0.09 log units) between middle value and limit.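

In this assay compound 3, which carries a bare hydroxy on the aromatic ring, gives > 20000 nM, which is a limit of the assay and not a number. The step between compound 2 and compound 3 cannot be read, because both values sit at the same ceiling: the limit of > 20000 nM in this assay, at which 2 of the 3 values shown sit.

Going by these compounds alone, the one readable step, an at least 1.5-fold higher number from compound 1 to compound 3 (0.18 log units; that floor lies within the scatter), shows that the core with only a hydroxy reaches no measurable growth inhibition, and it gives no firm sign that the (4-methyl-1,3-thiazol-5-yl)carbonyl group adds any.

As far as these compounds go, it stays open whether any group on this oxygen can bring the number well under the limit in this assay. A methyl ether or an ester carrying an amine would test this, and a true value for compound 3 would be needed to rank it against compound 2.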